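This account rests on a few compounds, and the source may have more. Where it says the series, first, only, none or still open, it means among the compounds named here.

Working notes on the series. The shared core carries an acylguanidine and a methylsulfonyl group, and the three measured compounds differ in what else sits on the ring. Compound 1 `Cc1cc(Br)c(C(=O)N=C(N)N)cc1S(C)(=O)=O` gives 70 nM in a functional assay for inhibition of sodium/hydrogen exchanger (Oryctolagus cuniculus); a lower number here means a stronger inhibitor, a higher number a weaker inhibitor. Compound 2 `Cc1ccc(-c2ccc(C(=O)N=C(N)N)cc2S(C)(=O)=O)cc1` gives 100 nM in this assay. Compound 3 `Cc1cc(-c2ccc(F)cc2)c(S(C)(=O)=O)cc1C(=O)N=C(N)N` gives 36 nM in this assay, the lowest of the three numbers; its gap to compound 1 lies within the scatter, so no order between these two can be claimed, while its gap to compound 2 lies beyond the scatter, and compound 3 is the stronger of that pair.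

Compound 4 `Cc1cc(OC2CCCC2)c(S(C)(=O)=O)cc1C(=O)N=C(N)N` has not been measured in this assay. It differs from compound 3 in one place: cyclopentyloxy in place of 4-fluorophenyl on an aromatic carbon. Within the data shown here, no measured pair shows this kind of change, so the size of the step cannot be read from any known step. The expectation is a small step, if any, in the direction of a higher number, and most likely within the scatter. On this basis compound 4 is expected to give about 60 nM in this assay, between 20 nM and 200 nM, which means an expected step of a 1.7-fold higher number from compound 3 to compound 4 (0.22 log units; within the scatter).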

Compound 4, half-maximal inhibitory concentration: 27 nM
For compound 4 the middle estimate is 2.2-fold (0.35 log units) above the measured one, within the range that was stated.
By their numbers in this assay, from the lowest: compounds 4, 3, 1 and 2 (each within the scatter of the next, the first and the last beyond it).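

The change from 4-fluorophenyl to cyclopentyloxy on the aromatic carbon ortho to a methylsulfonyl group gives a 1.3-fold lower number from compound 3 to compound 4 (0.12 log units; within the scatter) in this assay, so no order between these two compounds can be claimed. At this position, then, a six-membered aromatic ring of carbon only and a five-membered non-aromatic ring joined through oxygen give values that cannot be told apart in this read-out, even though the entering group carries a hydrogen-bond acceptor and the leaving group carries none. No supporting measurement bears on this result, so it stands as an observation on one pair of compounds.

Open, as far as these compounds go, is whether the ring or the oxygen link matters here, a question that a phenoxy group or a cyclopentyl group joined directly to the aromatic carbon would address. Also open, from the compounds shown here alone, is whether the values stay in this range with a primary amine, a carboxylic acid or a longer chain such as n-butoxy at the same place.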